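This account rests on a few compounds, and the source may have more. Where it says the series, first, only, none or still open, it means among the compounds named here.

In a functional assay on T98G cells (Homo sapiens) for inhibition, read by colorimetric assay and MTT assay, with a stated time of 72 h (on this read-out lower numbers stand for stronger inhibition and higher numbers for weaker inhibition), compound 1 (`Cn1c2cnc1OCCCCCCCCCCOc1ccccc1-2`) gives 41000 nM and compound 2 (`C=CCCCCOc1ccccc1-c1cnc(OCCCC=C)n1C`) gives 3000 nM. Compound 3 (`CCCCCCOc1ncc(-c2ccccc2OC)n1C`) gives 58000 nM, which lies within the scatter of compound 1 and beyond the scatter of compound 2, whose number is lower. Compound 4 (`C=CCCOc1ncc(-c2ccccc2OC)n1C`) has not yet been measured. It differs from compound 3 by vinyl in place of butyl on a saturated chain carbon, two bonds along the chain from an oxygen on an aromatic ring, with vinyl in place of butyl on a saturated chain carbon, two bonds along the chain from an oxygen on an aromatic ring. Going by the values given here, no measured pair isolates this change. Compound 2, at 3000 nM, also carries but-3-en-1-yl but differs elsewhere too, so no step beyond the scatter is expected. The expected step is a 1.2-fold lower number from compound 3 to compound 4 (0.06 log units; within the scatter). For compound 4 the estimated value is 50000 nM, with an expected range of 20000 nM to 120000 nM.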

Compound 4, half-maximal inhibitory concentration: 39000 nM
Beside the measured number, compound 4's estimate is 1.3-fold (0.11 log units) above it; low and high end bracket the measured number.
By their numbers in this assay, from the lowest: compound 2; then compounds 4, 1 and 3 (each within the scatter of the next).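

In this assay, going by these compounds alone, this pair gives the first direct reading of the change: a 1.5-fold lower number from compound 3 to compound 4 (0.17 log units; within the scatter). Replacing hexyl with but-3-en-1-yl, which shortens the chain and adds a double bond, therefore produces no shift beyond the scatter in this shared core. No evidence on the reason for this result is available.

The pair cannot separate the shorter chain from the double bond, since both change together. It also leaves open how an amine or a carboxylic acid in place of this chain would read out.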